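The compounds below may be only part of what the source reports. "The series", "measured", "known", "first", "only" and "open" are said of these compounds alone.

Of the compounds shown here, two from this series have been measured in an ADME assay (liver) for metabolic stability, with Liver microsome (Homo sapiens) as the target, read by LC-MS, using microsomes, tested at 1 uM (on this read-out higher numbers stand for a longer-lived compound and lower numbers for a shorter-lived compound), so far. Compound 1 `CNc1nc(NCCCN(C)C)c2sc(-c3ccc(S(C)(=O)=O)cc3)cc2n1` gives 1.92 h, and compound 2 `CNc1nc(NCCCN(C)C)c2sc(-c3ccccc3)cc2n1` gives 5.75 h. Among the compounds with values here, the one step recorded between them is a 3.0-fold higher number from compound 1 to compound 2 (0.48 log units; beyond the scatter), so compound 2 stands at the higher of the two numbers, and compound 1 is its only neighbour.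

Compound 3 `CNc1nc(NCCCN(C)C)c2sc(-c3cccc(C(F)(F)F)c3)cc2n1` is the next member to be read in this assay. Relative to compound 2 the change is trifluoromethyl in place of hydrogen on an aromatic carbon, on the ring that carries the aromatic carbon bearing the group, at the position described as meta to a large group.

Within the data shown here, no measured step places a trifluoromethyl on this ring, and the one step available concerns a different group at a different position, so it does not bear directly on the change at hand. The account therefore rests on compound 2 alone. Compound 3 is expected to fall near compound 2, with a step of a 1.2-fold lower number from compound 2 to compound 3 (0.06 log units; within the scatter) that need not exceed the scatter. The expectation for compound 3 in this assay is 5 h, within a range from 2.2 h to 11 h.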

Compound 3, half-life: 0.518 h
Compound 3: middle estimate off by 9.7-fold (0.98 log units), on the high side; the measured number lies below the stated range.
By their numbers in this assay, from the lowest: compound 3; then compound 1; then compound 2.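

In this assay, trifluoromethyl in place of hydrogen on an aromatic carbon, meta to a large group, gives an 11-fold lower number from compound 2 to compound 3 (1.05 log units; beyond the scatter), so this place on the ring is far from silent for this read-out. Within the data shown here, compound 2, which carries only hydrogen on this ring, now has the highest number of the three, and each of the two groups seen here, methylsulfonyl in compound 1 and trifluoromethyl in compound 3, comes with a lower number than compound 2; none of the three goes against this, but it rests on only two groups, which sit at different places on the ring. Nothing measured on these compounds speaks to what lies behind the drop, so the step stands as an observation only.

The compounds shown leave open whether the drop belongs to trifluoromethyl itself or to this place on the ring. A smaller group such as fluorine or methoxy at the same place, or trifluoromethyl moved elsewhere on the ring, would separate those two readings, and how far either would stay from compound 2 remains an open question.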